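The source may report more compounds than this note shows. Statements on the series, on what has been measured and on what is new or still open speak of the compounds shown alone.

Measured so far in a functional assay on IMR-32 cells (Homo sapiens) for antiproliferative activity, read by MTT assay (on this read-out lower numbers stand for stronger inhibition and higher numbers for weaker inhibition), are three compounds:
compound 1 `CC1(C)CCc2cc(C(=O)/C=C/c3ccc(OCc4cn(-c5ccc(Cl)cc5)nn4)cc3)c(O)cc2O1` gives 92100 nM
compound 2 `CCc1ccccc1-n1cc(COc2ccc(/C=C/C(=O)c3cc4c(cc3O)OC(C)(C)CC4)cc2)nn1` gives "not active" (no number reported)
compound 3 `CC1(C)CCc2c(ccc(C(=O)/C=C/c3ccc(OCc4cn(-c5ccc(Br)cc5)nn4)cc3)c2O)O1` gives 117000 nM

In this assay compound 3 (117000 nM) and compound 1 (92100 nM) lie within the usual scatter of each other. Compound 2 offers no number to set beside them, since it is reported only as ("not active" (no number reported)) in this series.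

Going by the values given here, compound 4 `CCc1ccccc1-n1cc(COc2ccc(/C=C/C(=O)c3ccc4c(c3O)CCC(C)(C)O4)cc2)nn1` keeps the core of compound 3 and carries 2-ethylphenyl in place of 4-bromophenyl on an aromatic nitrogen of a five-membered aromatic ring with 3 nitrogen 2-ethylphenyl in place of 4-bromophenyl on an aromatic nitrogen as its one change. The same 2-ethylphenyl stands in compound 2, whose entry ("not active" (no number reported)) holds no number, so the reading for compound 4 may likewise come back without one. If a number does appear, it is expected to stay close to the level of the two numbers already known. The expected step of a 1.1-fold higher number from compound 3 to compound 4 (0.05 log units; within the scatter) is small, leans towards weaker inhibition and does not go beyond the scatter. For compound 4 the estimated value is 130000 nM with an expected range from 60000 nM to 300000 nM in this assay should a number be reported at all.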

Compound 4, half-maximal inhibitory concentration: "not active" (no number reported)
No number was reported for compound 4, so the estimate cannot be set against anything.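

In this assay compound 4 gives "not active" (no number reported) and so offers no number, which means no step can be read between compound 3 and compound 4. No evidence bearing on this result is available. The compounds shown leave open whether 2-ethylphenyl and 4-bromophenyl differ by any measurable amount on the shared core.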